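The source may hold more compounds than are shown below. What is called first, only, known or untested is meant among the compounds shown, and "the series" means these compounds.

Compound 1 `C[C@@H](O)[C@H]1C(=O)N2C(C(=O)OCOC(=O)C3CCCCC3)=C(S[C@@H]3CN[C@H](C(=O)Nc4cccc(C(=O)O)c4)C3)[C@H](C)[C@H]12` gives > 95% in a physicochemical assay for metabolic stability, read by LC-MS, in phosphate buffer, with a stated time of 3 h, at pH 7.4, tested at 50 uM; on this read-out lower numbers stand for a less stable compound and higher numbers for a more stable compound. Compound 2 `C[C@@H](O)[C@H]1C(=O)N2C(C(=O)OCc3oc(=O)oc3C(C)(C)C)=C(S[C@@H]3CN[C@H](C(=O)Nc4cccc(C(=O)OCc5oc(=O)oc5C(C)(C)C)c4)C3)[C@H](C)[C@H]12` gives > 95% in this assay.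

The value for compound 1 is a limit of the assay rather than a number. The value for compound 2 is likewise a limit. Both therefore sit at the limit of > 95% in this assay, at which 2 of the 2 values shown sit, so nothing in these numbers places compound 1 above or below compound 2; it can only be said that compound 1 is reported as at least as stable as the assay can resolve.

Compound 3 `C[C@@H](O)[C@H]1C(=O)N2C(C(=O)OCC(F)(F)F)=C(S[C@@H]3CN[C@H](C(=O)Nc4cccc(C(=O)O)c4)C3)[C@H](C)[C@H]12` keeps the core of compound 1 and differs from it in one place: trifluoromethyl in place of (cyclohexylcarbonyl)oxy on a saturated chain carbon bound to an oxygen next to a carbonyl group. Within the data shown here, no measured pair shows what this exchange does in this assay. The step expected in this assay is a number no higher from compound 1 to compound 3 (the limit leaves the size open), which amounts to no change beyond the usual scatter, because compound 1 already stands at the limit of > 95% in this assay, at which 2 of the 2 values shown sit. For compound 3 the estimated read-out in this assay is 95%, expected to fall between 85% and 99%.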

Compound 3, percent of the compound remaining: > 95%
Compound 3: no number, only a limit (the forecaster's own chance of this, stated with the estimate: 65%); the middle value lies on the limit itself.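

In this assay compound 3 gives > 95% and this is a limit, not a number. Among these compounds, compound 1 also stands at a limit, so no step between compound 1 and compound 3 can be read. The compounds shown leave open whether trifluoromethyl in place of (cyclohexylcarbonyl)oxy changes the percent remaining at all.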